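Compound 3 to compound 4: working notes

The compounds below may be only part of what the source reports. "The series", "measured", "known", "first", "only" and "open" are said of these compounds alone.

In a toxicity assay on HepG2 2.2.15 cells (Homo sapiens) for cytotoxicity, read by CellTiter-Glo (on this read-out lower numbers stand for higher toxicity in this test and higher numbers for lower toxicity in this test), compound 1 (`O=C1NC(c2ccccc2)CN1c1cnn2c1CN(C(=O)Nc1cc(F)c(F)c(F)c1)C(C1CC1)C2`) gives 38500 nM, compound 2 (`Cc1cnc(C2CC(=O)N(c3cnn4c3CN(C(=O)Nc3cc(F)c(F)c(F)c3)C(C3CC3)C4)C2)s1`) gives 96200 nM and compound 3 (`O=C1CC(c2ncc(F)cn2)CN1c1cnn2c1CN(C(=O)Nc1cc(F)c(F)c(F)c1)C(C1CC1)C2`) gives 115000 nM. Compound 3 stands level with compound 2 within the scatter, and the number of compound 1 is the lowest of the three.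

Compound 4 (`O=C1CC(c2ccccn2)CN1c1cnn2c1CN(C(=O)Nc1cc(F)c(F)c(F)c1)C(C1CC1)C2`) carries pyridin-2-yl in place of 5-fluoropyrimidin-2-yl on a saturated ring carbon.

Going by the values given here, the closest precedent is an exchange of one aromatic group for another at this same carbon, a 1.2-fold higher number from compound 2 to compound 3 (0.08 log units; within the scatter), and it stays within the scatter. The other measured step, a 2.5-fold higher number from compound 1 to compound 2 (0.40 log units; beyond the scatter), is modest, but it replaces the whole group on an aromatic carbon and so bears less directly on this change. No step beyond the scatter is therefore expected in this assay. The expected step is a 1.2-fold lower number from compound 3 to compound 4 (0.08 log units; within the scatter), with no firm direction. The estimated value for compound 4 is 95000 nM, with an expected range from 50000 nM to 170000 nM.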

Compound 4, half-maximal cytotoxic concentration: 96200 nM
Beside the measured number, compound 4's estimate is 1.0-fold (0.01 log units) below it; the measured number falls inside the stated range.
By their numbers in this assay, from the lowest: compound 1; then compounds 2, 4 and 3 (each within the scatter of the next).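

At the saturated ring carbon, a third aromatic group changes little in this assay: a 1.2-fold lower number from compound 3 to compound 4 (0.08 log units; within the scatter), and no change at the digits printed from compound 2 to compound 4 (within the scatter), so the shown pyridin-2-yl, 5-fluoropyrimidin-2-yl and 5-methyl-1,3-thiazol-2-yl groups cannot be told apart in this read-out, even with the fluorine gone and one ring hetero atom fewer than in 5-fluoropyrimidin-2-yl. Exchange of the whole group on the aromatic carbon remains the only kind of change here to go beyond the scatter, with a 2.5-fold higher number from compound 1 to compound 4 (0.40 log units; beyond the scatter). No measurement here accounts for the flat response at this carbon or for the separate position of compound 1.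

Every group shown at the saturated ring carbon is aromatic, so the effect of an amine, a carboxylic acid or a longer alkyl chain there remains open. The step from compound 1 also changes both the ring and its aromatic group, which leaves the share of each unresolved.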